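This account rests on a few compounds, and the source may have more. Where it says the series, first, only, none or still open, it means among the compounds named here.

Measured in a functional assay on MGC-803 cells (Homo sapiens) for inhibition, read by MTT assay, with a stated time of 72 h; on this read-out higher numbers stand for weaker inhibition and lower numbers for stronger inhibition:
- compound 1 `Cc1cc(N2CC[C@@H](C)[C@@H](N(C)c3ncnc4[nH]ccc34)C2)n2nc(SCc3csc4ccc(Cl)cc34)nc2n1`: > 100000 nM
- compound 2 `CCCCCc1c(C)nc2nc(SCc3ccc(Cl)cc3)nn2c1N1CC[C@@H](C)[C@@H](N(C)c2ncnc3[nH]ccc23)C1`: > 100000 nM

Both entries are limits, not numbers. Going by the values given here, compound 1 stands at the limit of > 100000 nM in this assay, at which 2 of the 2 values shown sit, so no potency order can be read between the two compounds, and no measured step is available.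

Compound 3 `COc1ccc(CSc2nc3nc(C)cc(N4CC[C@@H](C)[C@@H](N(C)c5ncnc6[nH]ccc56)C4)n3n2)cc1` carries 4-methoxyphenyl in place of 5-chloro-1-benzothiophen-3-yl on a saturated chain carbon bound to a sulfur. The core of compound 1 is otherwise kept.

With only the limit of > 100000 nM in this assay, at which 2 of the 2 values shown sit, to go on, no change beyond the usual scatter is expected in this assay, and another limit is the likeliest result. The estimated step is a number no higher from compound 1 to compound 3 (the limit leaves the size open). For compound 3 the estimated value is 100000 nM, with an expected range of 30000 nM to 300000 nM.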

Compound 3, half-maximal inhibitory concentration: 15200 nM
For compound 3 the middle estimate is 6.6-fold (0.82 log units) above the measured one; measured number outside the range, below it.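

In this assay, the position on a saturated chain carbon bound to a sulfur proves able to bring the read-out off the limit: 4-methoxyphenyl in place of 5-chloro-1-benzothiophen-3-yl gives an at least 6.5-fold lower number from compound 1 to compound 3 (0.81 log units; beyond the scatter). The core of compound 1 is otherwise kept, so this step belongs to this one change, in which a group with a five-membered and a six-membered aromatic ring gives way to a group with a single six-membered aromatic ring. Only a minimum can be given for the step, and its full size stays open, since compound 1 is a limit: the limit of > 100000 nM in this assay, at which 2 of the 3 values shown sit.

From the compounds shown here alone, whether the lower number follows from the loss of the 5-chloro-1-benzothiophen-3-yl group or from the methoxy group itself stays open. Equally open, going by these compounds, is how an unsubstituted benzyl or a 4-aminobenzyl would read at this position, and compound 2 differs from compound 3 in more than one place, so it cannot settle this.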